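A Ring Opened on the Amino Side Chain

The compounds below may be only part of what the source reports. "The series", "measured", "known", "first", "only" and "open" are said of these compounds alone.

- compound 1 `CC(C)c1n[nH]c2c(NCc3ccc(-c4ccccn4)cc3)nc(N3CCCCC3CCO)nc12`: 133 nM
- compound 2 `CC(C)c1n[nH]c2c(NCc3ccc(-c4ccccn4)cc3)nc(N[C@@H]3CCCC[C@H]3N)nc12`: 295 nM

In a functional assay on MCF7 cells (Homo sapiens) for cytotoxicity, read by fluorescence, with a stated time of 72 h (a higher number here means a weaker inhibitor, a lower number a stronger inhibitor), compound 2 gives 295 nM, the higher of the two numbers, and compound 1 gives 133 nM. Compound 3 `CC(C)c1n[nH]c2c(NCc3ccc(-c4ccccn4)cc3)nc(NCC(N)CO)nc12` has not yet been measured. It carries 2-amino-3-hydroxypropyl in place of 2-aminocyclohexyl on a nitrogen on an aromatic ring. Within the data shown here, only one measured step bears on this change, a 2.2-fold higher number from compound 1 to compound 2 (0.35 log units; beyond the scatter), which replaced a different group at the same part of the molecule and was modest. That single step gives little guidance on direction, so no shift beyond the scatter is expected in this assay. The estimated step is a 1.0-fold higher number from compound 2 to compound 3 (0.01 log units; within the scatter). For compound 3 the expected value is 300 nM, with an estimated range from 110 nM to 800 nM.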

Compound 3, half-maximal inhibitory concentration: 310 nM
For compound 3 the middle estimate is 1.0-fold (0.01 log units) below the measured one, and the stated range covers the measured number.
By their numbers in this assay, from the lowest: compound 1; then compounds 2 and 3 (each within the scatter of the next).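

In this assay, the open chain 2-amino-3-hydroxypropyl replaces 2-aminocyclohexyl on the nitrogen with a 1.1-fold higher number from compound 2 to compound 3 (0.02 log units; within the scatter) as the step, so for this pair the six-membered carbon ring can go without a shift beyond the scatter. The same chain still differs from the 2-(2-hydroxyethyl)piperidin-1-yl group on the aromatic carbon, with a 2.3-fold higher number from compound 1 to compound 3 (0.37 log units; beyond the scatter) as the step, which places compound 2 and compound 3 together and leaves compound 1 alone with the lowest number. No measurement here accounts for these numbers.

The compounds shown leave open whether a chain with the amine alone, or with the hydroxyl alone, would stay at this level. They also do not show what a carboxylic acid or a longer chain on this nitrogen would do in this cell assay.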